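The compounds below may be only part of what the source reports. "The series", "measured", "known", "first", "only" and "open" are said of these compounds alone.

Going by the values given here, in a functional assay on HL-60 cells (Homo sapiens) for inhibition, read by MTT assay, with a stated time of 72 h (on this read-out lower numbers stand for stronger inhibition and higher numbers for weaker inhibition), compound 2 (`Cc1nc(-c2ccccc2)c(C(=O)N2CCN(c3ccccc3)CC2)o1`) gives 39.1 nM as the only actual number so far. Compound 1 (`Cc1ccc(N2CCN(C(=O)c3oc(C)nc3-c3ccccc3)CC2)cc1`) gives > 1000 nM and that is only a limit of the assay. Compound 3 (`Cc1nc(-c2ccccc2)c(C(=O)N2CCN(c3ccc(C)c(C)c3)CC2)o1`) has 3,4-dimethylphenyl in place of phenyl on an amine nitrogen in a ring. Among the compounds with values here, the only measured step bearing on this is an at least 25-fold lower number from compound 1 to compound 2 (1.40 log units; beyond the scatter) with hydrogen in place of methyl on an aromatic carbon. It is large, so a clearly higher number is expected in this assay on adding methyl, though one pair is thin support. a 7.7-fold higher number from compound 2 to compound 3 (0.88 log units; beyond the scatter) is the expected step. Compound 3 is estimated at 300 nM (range 40 nM to 2000 nM).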

Compound 3, half-maximal inhibitory concentration: 43 nM
Compound 3: the middle estimate sits 7.0-fold (0.84 log units) above what was measured, within the range that was stated.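

In this assay, 3,4-dimethylphenyl in place of phenyl on this amine nitrogen gives a 1.1-fold higher number from compound 2 to compound 3 (0.04 log units; within the scatter), so methyl groups on this ring do not in themselves raise the number. Methyl in place of hydrogen on an aromatic carbon also gives an at least 23-fold lower number from compound 1 to compound 3 (1.36 log units; beyond the scatter), the opposite direction to the earlier step, so the effect of methyl here is not uniform. This step rests on a limit for compound 1, not a number: the limit of > 1000 nM in this assay, at which 1 of the 3 values shown sits.

From the compounds shown here alone, what a methoxy group, a chlorine atom or an amine on this ring would do stays open.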